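The compounds below may be only part of what the source reports. "The series", "measured", "known", "first", "only" and "open" are said of these compounds alone.

Measured in an assay on isolated protein for inhibition of CD40-CD40L (Homo sapiens), read by ELISA, with a stated time of 1 h; a lower number here means a stronger inhibitor, a higher number a weaker inhibitor:
compound 1 `O=C(Nc1ccc(-c2ccc(C(=O)Nc3ccc(S(=O)(=O)O)c4ccccc34)cc2)cc1)c1ccc([N+](=O)[O-])cc1` gives 2330 nM
compound 2 `O=C(Nc1ccc(C(=O)Nc2cccc3cccc(S(=O)(=O)O)c23)cc1)c1ccc([N+](=O)[O-])cc1` gives 342000 nM

Compound 1 stands at the lower of the two numbers; compound 2 sits far higher, a gap well beyond the scatter. The two differ in more than one place, so no single step can be read from them. Compound 3 `O=C(Nc1ccc(-c2ccc(C(=O)Nc3ccc(C(=O)O)c4ccccc34)cc2)cc1)c1ccc([N+](=O)[O-])cc1` follows from compound 1 by one change: carboxy in place of sulfo on an aromatic carbon. A step toward a higher number, beyond the scatter, is expected here; the expected step is a 5.2-fold higher number from compound 1 to compound 3 (0.71 log units; beyond the scatter). Compound 3 is estimated at 12000 nM, within a range from 2500 nM to 60000 nM.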

Compound 3, half-maximal inhibitory concentration: 360 nM
Compound 3: middle estimate off by 33-fold (1.52 log units), on the high side; the measured number lies below the stated range.
By their numbers in this assay, from the lowest: compound 3; then compound 1; then compound 2.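

In this assay, among these compounds, carboxy in place of sulfo on an aromatic carbon para to a large group gives a 6.5-fold lower number from compound 1 to compound 3 (0.81 log units; beyond the scatter) in the first single-place comparison of the series. The sulfo group of compound 1 is therefore not needed at this place to reach a low number, and the change runs toward a lower number. No measurement available here bears on why the step runs this way.

Still open, from the compounds shown here alone, is whether a tetrazole, a primary amide or a methyl ester at this place would move the number further. Also open, going by these compounds, is whether the same change holds on the core of compound 2.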